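Swapping Methoxy for Chloro on a Weak Antiproliferative

The source may report more compounds than this note shows. Statements on the series, on what has been measured and on what is new or still open speak of the compounds shown alone.

Compound 1 `O=C1COc2ccc(-c3cnc(Cl)c(NS(=O)(=O)c4ccc(F)cc4)c3)cc2N1C1CCCCC1`: 14300 nM
Compound 2 `COc1ncc(-c2ccc3c(c2)N(C2CC2)C(=O)CO3)cc1NS(=O)(=O)c1ccc(F)cc1`: 6030 nM

In a functional assay on HeLa cells (Homo sapiens) for antiproliferative activity, read by MTT assay, with a stated time of 72 h (on this read-out lower numbers stand for stronger inhibition and higher numbers for weaker inhibition), compound 2 gives 6030 nM, the lower of the two numbers, and the gap to compound 1 lies beyond the usual scatter. The next molecule, compound 3 `O=C1COc2ccc(-c3cnc(Cl)c(NS(=O)(=O)c4ccc(F)cc4)c3)cc2N1C1CC1`, has chloro in place of methoxy on an aromatic carbon next to the ring nitrogen: chloro in place of methoxy on an aromatic carbon. For the measured compounds named here, no measured pair shows this change on its own. Going by the values given here, the only guide is compound 1, which also carries chloro and gives 14300 nM, so a small rise in the number is expected in this assay, possibly no larger than the scatter. The expected size of this change is a 1.3-fold higher number from compound 2 to compound 3 (0.12 log units; within the scatter). For compound 3 the estimated value is 8000 nM, with an expected range of 2800 nM to 20000 nM.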

Compound 3, half-maximal inhibitory concentration: 7180 nM
For compound 3 the middle estimate is 1.1-fold (0.05 log units) above the measured one; measured number inside the range.
By their numbers in this assay, from the lowest: compounds 2, 3 and 1 (each within the scatter of the next, the first and the last beyond it).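

Compounds 1 and 2 differ in two places at once. Compound 3 differs from each of them in only one place, and so it separates the two changes. In this assay, chloro in place of methoxy on the aromatic carbon next to the ring nitrogen gives a 1.2-fold higher number from compound 2 to compound 3 (0.08 log units; within the scatter) and so leaves no readable difference between these two groups at this position. With chloro kept in place, cyclopropyl in place of cyclohexyl on the amide-type nitrogen in a ring gives a 2.0-fold lower number from compound 1 to compound 3 (0.30 log units; within the scatter) and so also stays too small to read as a real difference.

From the compounds shown here alone, whether an amine or a carboxylic acid on that aromatic carbon would move the number beyond the scatter remains open. Nothing available accounts for either step.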